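Quinazoline series, melatonin receptor type 1B: urea to cyclopropyl amide

A few compounds are considered here, and "the series" means these few. Any claim that something is new, unique, unknown or untested is made for them only; others in the source may bear on it.

Measured so far:
- compound 1 `COc1ccc2ncnc(NCCNC(C)=O)c2c1`: > 100000 nM
- compound 2 `CCNC(=O)N1CCN(c2ncnc3ccc(OC)cc23)CC1`: 2800 nM

In an assay on CHO cells for displacement of a labelled ligand from melatonin receptor type 1B (Homo sapiens), read by radioligand binding, with a stated time of 120 min (a lower number here means a stronger inhibitor, a higher number a weaker inhibitor), compound 1 returns only a limit, > 100000 nM, and no number. Among the measured compounds shown here, compound 2 gives 2800 nM in this assay, the only number so far in the set. The other value, that of compound 1, sits at the limit (the limit of > 100000 nM in this assay, at which 1 of the 2 values shown sits). Compound 2 thus stands alone as the single measured point from which any expectation has to be drawn.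

Compound 3 `COc1ccc2ncnc(N3CCN(C(=O)C4CC4)CC3)c2c1` is not yet measured. It differs from compound 2 in one place: cyclopropyl in place of ethylamino on a carbonyl carbon. The piperazine attached to the shared core stays, and the carbonyl stays; only what sits on the far side of that carbonyl changes, the ethylcarbamoyl becoming a cyclopropylcarbonyl. For the measured compounds named here, no measured step of this kind exists in the set, so the size of the change rests on judgement only. The step of a 1.4-fold lower number from compound 2 to compound 3 (0.15 log units; within the scatter) is expected to be small, likely none beyond the usual scatter of this assay. Compound 3 is accordingly estimated at 2000 nM, with a plausible range from 500 nM to 8000 nM.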

Compound 3, inhibition constant: 3300 nM
For compound 3 the middle estimate is 1.7-fold (0.22 log units) below the measured one; the range from low to high includes it.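

In this assay, among the compounds shown here, the exchange of ethylamino for cyclopropyl on a carbonyl carbon gives a 1.2-fold higher number from compound 2 to compound 3 (0.07 log units; within the scatter) as the first measured step, and so the first reading of how this position responds to a change. The amide-type nitrogen in a ring and the carbonyl stay in place, while the hydrogen-bond donor counted on ethylamino leaves and a three-membered ring of carbon enters, and compound 2 and compound 3 remain within the scatter of each other. At this place, then, the series tolerates the loss of that donor and the move from ethylcarbamoyl to cyclopropylcarbonyl with no readable change, though no measured property in the set bears on the reason for this result.

Whether that tolerance extends to other groups on the same carbonyl carbon, such as a longer chain, a phenyl ring or a methoxy group, stays open, since ethylamino and cyclopropyl are the only two shown there. From the compounds shown here alone, compound 1 with > 100000 nM is a limit and not a number, and it differs from compound 2 in more than one place, so what the piperazine contributes also stays open.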